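The source may hold more compounds than are shown below. What is called first, only, known or untested is meant among the compounds shown, and "the series" means these compounds.

Measured compounds:
- Compound 1 `COc1cc(NC(=O)C2COc3ccccc3C2)ccc1-c1cn[nH]c1`: 7 nM
- Compound 2 `COc1cc(NC(=O)C2COc3ccccc3C2)c(F)cc1-c1cn[nH]c1`: 8 nM

In an assay on cells for inhibition of Rho-associated protein kinase 2 (Homo sapiens) (a lower number here means a stronger inhibitor, a higher number a weaker inhibitor), compound 1 gives 7 nM, and compound 2 sits within the scatter of it, so the two numbers are indistinguishable. Compound 3 `COc1ccc2c(c1)CC(C(=O)Nc1ccc(-c3cn[nH]c3)c(OC)c1)CO2` differs from compound 1 by methoxy in place of hydrogen on an aromatic carbon. For the measured compounds named here, the only measured step, a 1.1-fold higher number from compound 1 to compound 2 (0.06 log units; within the scatter), touches a different ring, so it bears on this change only loosely; it shows that a small substituent added to the shared core left the number unchanged. A step of a 1.4-fold higher number from compound 1 to compound 3 (0.15 log units; within the scatter) is therefore expected, one that would stay within the scatter. Compound 3 is estimated at 10 nM, with a range of 4 nM to 25 nM.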

Compound 3, half-maximal inhibitory concentration: < 6 nM
Compound 3: no number, only a limit (the forecaster's own chance of this, stated with the estimate: 0%); middle value at least 1.6-fold (0.22 log units) from the limit.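

In this assay compound 3 gives < 6 nM, which is a limit of the assay and not a number: the limit of < 6 nM in this assay, at which 1 of the 3 values shown sits. The step, an at least 1.1-fold lower number from compound 1 to compound 3 (0.06 log units; that floor lies within the scatter), shows that this aromatic carbon of the fused system can carry a methoxy without the number rising, something the earlier fluoro change on the other ring could not show. How far the true value of compound 3 lies beyond that floor cannot be read from a limit.

The compounds shown leave open whether an amine, a carboxylic acid or a longer chain at this carbon would keep the number as low.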